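From pyridin-3-yl to pyridin-4-yl: an expected small step

This account rests on a few compounds, and the source may have more. Where it says the series, first, only, none or still open, it means among the compounds named here.

compound 1 `Cc1cn2c(/C=N/NC(=N)N)c(-c3ccncc3)nc2s1`: 16600 nM
compound 2 `N=C(N)N/N=C/c1c(-c2cccnc2)nc2sc(Cl)cn12`: 20000 nM

Among the compounds with values here, only two compounds have numbers so far. In a functional assay on NSCLC cells (Homo sapiens) for antiproliferative activity (a higher number here means a weaker inhibitor of growth, a lower number a stronger inhibitor of growth), compound 2 gives 20000 nM and compound 1 gives 16600 nM, two values within the usual scatter of repeated measurements, so neither can be ranked above the other.

Compound 3 `N=C(N)N/N=C/c1c(-c2ccncc2)nc2sc(Cl)cn12` has not yet been measured. It differs from compound 2 in one place, with pyridin-4-yl in place of pyridin-3-yl on an aromatic carbon. The two have the same atoms, joined differently. Within the data shown here, no measured pair shows this swap on its own, so the evidence is thin. Compound 1 also carries pyridin-4-yl, although it is not identical to compound 3 elsewhere. Set against compound 2, compound 1 at 16600 nM lies within the scatter. In this assay no change beyond the scatter is therefore expected, and neither direction is favoured. The estimated step of a 1.2-fold lower number from compound 2 to compound 3 (0.07 log units; within the scatter) is small. For compound 3 the expected value is 17000 nM, with an estimated range from 7000 nM to 40000 nM.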

Compound 3, concentration for 50% growth inhibition: 6760 nM
The estimate for compound 3 lay 2.5-fold (0.40 log units) above the measured number; measured number outside the range, below it.
By their numbers in this assay, from the lowest: compound 3; then compounds 1 and 2 (each within the scatter of the next).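

In this assay the step of a 3.0-fold lower number from compound 2 to compound 3 (0.47 log units; beyond the scatter) comes from a swap of pyridin-3-yl for pyridin-4-yl, two groups with the same atoms joined differently, so on this aromatic carbon of the shared core the way the pyridine ring is attached matters, and the change is modest but beyond the scatter. With pyridin-4-yl held constant, the step of a 2.5-fold lower number from compound 1 to compound 3 (0.39 log units; beyond the scatter) goes with chloro in place of methyl on an aromatic carbon, which shows that a second site on the core also moves the number by a modest amount beyond the scatter. Nothing shown here gives a measured reason for either step.

Within the data shown here, what remains open is whether the preference for pyridin-4-yl over pyridin-3-yl also holds when methyl replaces chloro, since the only pair that isolates this swap carries chloro. It is also unknown how a plain phenyl ring or a pyridine bearing an amine would compare with pyridin-4-yl at this place, and whether bromo would compare with chloro at the other site.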